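The compounds below may be only part of what the source reports. "The series", "measured", "known", "first", "only" and "open" are said of these compounds alone.

Compound 1 `O=S(=O)(NCCCNCc1ccccc1Cl)c1cc(C(F)(F)F)cc(C(F)(F)F)c1` carries a 2-chlorophenyl group on a saturated chain carbon bound to an amine nitrogen. Within the data shown here, in a functional assay on Capan-2 cells (Homo sapiens) for inhibition, read by MTT assay, with a stated time of 72 h (on this read-out lower numbers stand for stronger inhibition of growth and higher numbers for weaker inhibition of growth), compound 1 gives 13000 nM, the second highest of the three numbers measured so far. Compound 2 `COc1ccc(CNCCCNS(=O)(=O)c2cc(C(F)(F)F)cc(C(F)(F)F)c2)cc1OC` gives 15000 nM in this assay, and compound 3 `O=S(=O)(NCCCNCc1cccc(Cl)c1)c1cc(C(F)(F)F)cc(C(F)(F)F)c1` gives 8000 nM. The step of a 1.2-fold higher number from compound 1 to compound 2 (0.06 log units; within the scatter) and the step of a 1.6-fold lower number from compound 1 to compound 3 (0.21 log units; within the scatter) both stay within the scatter, as does the step of a 1.9-fold lower number from compound 2 to compound 3 (0.27 log units; within the scatter). Compound 4 `O=S(=O)(NCCCNCc1ccc(Cl)cc1)c1cc(C(F)(F)F)cc(C(F)(F)F)c1` differs from compound 1 in one place: 4-chlorophenyl in place of 2-chlorophenyl on a saturated chain carbon bound to an amine nitrogen. The step from compound 1 to compound 3, which puts 3-chlorophenyl in place of 2-chlorophenyl at the same position, bears most directly on this change and was within the scatter; the other two measured steps, which exchange the same group for 3,4-dimethoxyphenyl, were also within the scatter. No step beyond the scatter is therefore expected in this assay for compound 4. Compound 4 is expected to give 10000 nM, with a range from 5000 nM to 25000 nM. This estimate means the expected step of a 1.3-fold lower number from compound 1 to compound 4 (0.11 log units; within the scatter).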

Compound 4, concentration for 50% growth inhibition: 2700 nM
The estimate for compound 4 lay 3.7-fold (0.57 log units) above the measured number, outside the stated range (below it).
By their numbers in this assay, from the lowest: compound 4; then compounds 3, 1 and 2 (each within the scatter of the next).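

In this assay this position, a saturated chain carbon bound to an amine nitrogen, now proves sensitive to where the chlorine stands on the phenyl ring: 4-chlorophenyl in place of 2-chlorophenyl gives a 4.8-fold lower number from compound 1 to compound 4 (0.68 log units; beyond the scatter) and 4-chlorophenyl in place of 3-chlorophenyl gives a 3.0-fold lower number from compound 3 to compound 4 (0.47 log units; beyond the scatter) even though the 2-chlorophenyl and 3-chlorophenyl groups had stayed within the scatter of each other. The exchange for 3,4-dimethoxyphenyl, a 5.6-fold lower number from compound 2 to compound 4 (0.74 log units; beyond the scatter) also lies beyond the scatter, so 4-chlorophenyl is the one group of the four shown that stands apart, with the strongest inhibition of growth. No measurement is at hand that would account for this difference.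

The compounds shown leave open whether 4-bromophenyl, 4-methoxyphenyl or 3,4-dichlorophenyl would match 4-chlorophenyl at this place. They also leave open whether the step would hold on a longer chain in the shared core.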